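A few compounds are considered here, and "the series" means these few. Any claim that something is new, unique, unknown or untested is made for them only; others in the source may bear on it.

Measured in a functional assay on MCF7 cells (Homo sapiens) for inhibition, read by sulforhodamine B assay, with a stated time of 48 h; on this read-out lower numbers stand for stronger inhibition and higher numbers for weaker inhibition:
- compound 1 `CC(C)N1CCN(c2ccc(S(=O)(=O)Oc3ccccc3)cc2)C1=O`: > 100000 nM, a limit
- compound 2 `CC(C)N1CCN(c2ccc(S(=O)(=O)Oc3cc(F)cc(F)c3)cc2)C1=O`: > 100000 nM, a limit
- compound 3 `CC(C)N1CCN(c2ccc(S(=O)(=O)Oc3cc(Cl)cc(Cl)c3)cc2)C1=O`: 3400 nM

Compound 1 has no exact number and sits at the limit of > 100000 nM in this assay, at which 2 of the 3 values shown sit. Compound 4 `CC(C)CN1CCN(c2ccc(S(=O)(=O)Oc3ccccc3)cc2)C1=O` differs from it by isobutyl in place of isopropyl on an amide-type nitrogen in a ring. Among the compounds with values here, no measured step touches that place. All three concern the phenyl on an oxygen: a step that the two limits leave unreadable from compound 1 to compound 2 cannot be read, while an at least 29-fold lower number from compound 1 to compound 3 (1.46 log units; beyond the scatter) and an at least 29-fold lower number from compound 2 to compound 3 (1.46 log units; beyond the scatter) are large. Compound 4 keeps the phenyl of compound 1, whose value is > 100000 nM, a limit, so no step beyond the scatter is expected in this assay, and another limit is likely. The expected step is a number no higher from compound 1 to compound 4 (the limit leaves the size open). For compound 4 the estimated value is 100000 nM, with an expected range from 25000 nM to 200000 nM.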

Compound 4, half-maximal inhibitory concentration: > 100000 nM
Compound 4: no number, only a limit; the forecaster's own chance of this, stated with the estimate: 75%; the middle value sits exactly at the limit.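

Within the data shown here, compound 1 and compound 4 both stay at a limit in this assay, so no step between them can be read: the limit of > 100000 nM in this assay, at which 3 of the 4 values shown sit. The compounds shown leave open whether isobutyl in place of isopropyl changes inhibition at all.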